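Rearranged dimethoxypyrimidine on a shared thiourea sulfonamide core

This account rests on a few compounds, and the source may have more. Where it says the series, first, only, none or still open, it means among the compounds named here.

Compound 1 `N=C(N)NS(=O)(=O)c1ccc(N/C(S)=N\c2ccnc3cc(C(F)(F)F)ccc23)cc1` — 33500 nM
Compound 2 `COc1cc(NS(=O)(=O)c2ccc(N/C(S)=N\c3ccnc4cc(C(F)(F)F)ccc34)cc2)nc(OC)n1` — 76700 nM

The two measured compounds share a core and differ only in the group on the sulfonamide nitrogen. In a functional assay on HepG2 cells (Homo sapiens) for antiproliferative activity, read by sulforhodamine B assay, with a stated time of 48 h (a lower number here means a stronger inhibitor, a higher number a weaker inhibitor), compound 1 gives 33500 nM. Compound 2 gives 76700 nM, the higher of the two numbers, and it stands as the weaker inhibitor of the pair because of the step of a 2.3-fold higher number from compound 1 to compound 2 (0.36 log units; beyond the scatter).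

Compound 3 `COc1ncnc(NS(=O)(=O)c2ccc(N/C(S)=N\c3ccnc4cc(C(F)(F)F)ccc34)cc2)c1OC` is not yet measured. Relative to compound 2 it carries 5,6-dimethoxypyrimidin-4-yl in place of 2,6-dimethoxypyrimidin-4-yl on a sulfonamide nitrogen. Among the measured compounds shown here, the single measured step, a 2.3-fold higher number from compound 1 to compound 2 (0.36 log units; beyond the scatter), exchanged one group for another of different size and does not bear directly on a rearrangement of the same atoms, so there is no precedent here. With nothing pointing in either direction, the step of a 1.1-fold lower number from compound 2 to compound 3 (0.04 log units; within the scatter) is expected to stay within the scatter. Compound 3 is therefore estimated at 70000 nM, with a range from 30000 nM to 170000 nM.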

Compound 3, half-maximal inhibitory concentration: 77300 nM
Estimate against measurement, compound 3: 1.1-fold (0.04 log units) below, and the stated range covers the measured number.
By their numbers in this assay, from the lowest: compound 1; then compounds 2 and 3 (each within the scatter of the next).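

In this assay, moving from the 2,6-dimethoxypyrimidin-4-yl to the 5,6-dimethoxypyrimidin-4-yl group on the sulfonamide nitrogen gives a 1.0-fold higher number from compound 2 to compound 3 (0.00 log units; within the scatter), so these two arrangements of the same atoms cannot be told apart here. Compared with the smaller, ring-free group of compound 1, the new group gives a 2.3-fold higher number from compound 1 to compound 3 (0.36 log units; beyond the scatter), which matches the earlier step of a 2.3-fold higher number from compound 1 to compound 2 (0.36 log units; beyond the scatter); both dimethoxypyrimidine compounds therefore give higher numbers than compound 1, and neither goes against this within the three compounds. No measured evidence bears on this result.

From the compounds shown here alone, what remains open is whether the methoxy groups matter at all, which a pyrimidine without them or one bearing amine groups could test. Going by these compounds, it is also open whether a quite different group on this nitrogen, such as a pyridine or a carboxylic acid-bearing chain, would shift the number in either direction.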